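A second methoxy group on the aryl ring of compound 1

This account rests on a few compounds, and the source may have more. Where it says the series, first, only, none or still open, it means among the compounds named here.

Compound 1 `COc1ccc(NC(=S)N/N=C2\C(=O)Nc3ccc([N+](=O)[O-])cc32)cc1` is one of two measured analogues built on the same core. In a functional assay on the whole organism for inhibition, with Lemna aequinoctialis as the target, tested at 10 ug/mL (on this read-out higher numbers stand for more inhibition of growth at the one concentration tested and lower numbers for less inhibition of growth), compound 1 gives 10%. For the measured compounds named here, its only measured neighbour, compound 2 `N#Cc1cccc(NC(=S)N/N=C2\C(=O)Nc3ccc([N+](=O)[O-])cc32)c1`, gives 5% in this assay. Compound 1 thus has the higher of the two numbers shown, but the step of a number 5 percentage points lower from compound 1 to compound 2 (within the scatter) lies within the scatter, so the two values cannot be told apart. Compound 3 `COc1ccc(NC(=S)N/N=C2\C(=O)Nc3ccc([N+](=O)[O-])cc32)c(OC)c1` is not yet measured; it differs from compound 1 by methoxy in place of hydrogen on an aromatic carbon, so that the aryl group on the amide-type nitrogen now carries two methoxy groups. Going by the values given here, the only measured step that bears on this, a number 5 percentage points lower from compound 1 to compound 2 (within the scatter), exchanged the whole aryl group and still stayed within the scatter, which gives no ground to expect a change beyond the scatter from a smaller alteration of the same aryl group. Both measured numbers sit at the low end of the scale. Compound 3 is therefore expected to show a step of no change at the digits printed from compound 1 to compound 3 (within the scatter) in this assay, nothing beyond the scatter. The estimate for compound 3 in this assay is 10%, with a range from 0% to 25%.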

Compound 3, percent growth inhibition at one concentration: 15%
The estimate for compound 3 lay 5 percentage points below the measured number; measured number inside the range.
By their numbers in this assay, from the lowest: compounds 2, 1 and 3 (each within the scatter of the next).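

In this assay, placing a methoxy group on the aromatic carbon ortho to a large group and meta to a methoxy group gives a number 5 percentage points higher from compound 1 to compound 3 (within the scatter), so at this position the added methoxy group cannot be told apart from hydrogen. For the compounds shown here, the earlier step exchanged one whole aryl group for another, whereas this one is the first reading of a single added group on the aryl ring of compound 1, and it shows that adding this group here does not carry the number beyond the scatter. Nothing available on these compounds offers an explanation for this result.

All three numbers sit at the low end of the scale, so the compounds shown leave open whether any change on this aryl ring can raise growth inhibition beyond the scatter. As far as these compounds go, it also remains open whether a different group at this same position, such as an amine, a carboxylic acid or a longer chain in place of the methoxy group, would give a number that stands clear of compound 1.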